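Aryl ether swap on the shared bicyclic amine core

The compounds below may be only part of what the source reports. "The series", "measured", "known", "first", "only" and "open" are said of these compounds alone.

Measured in an in vitro assay on HEK293 cells with metabotropic glutamate receptor 2 (Rattus norvegicus) as the target, read by FLIPR, in the presence of a further agent that is not named here; a higher number here means that more compound is needed for the effect, a lower number that less compound is needed:
compound 1 `c1ccc(OCC2[C@H]3CN(Cc4nc5ccccc5n4C4CC4)C[C@@H]23)cc1` gives 3020 nM
compound 2 `Cn1c(CN2C[C@@H]3C(COc4cc(F)ccc4F)[C@@H]3C2)nc2ccccc21` gives 7 nM

Compound 2 holds the lowest of the two numbers in this assay. Its nearest neighbour is compound 1, whose number is far higher, a gap well beyond the scatter of repeated runs. Within the data shown here, the two compounds differ in more than one place, so no single step between them is described; the two values are stated as they stand and nothing more is read into their difference.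

Compound 3 `Cn1c(CN2C[C@@H]3C(COc4ccc(Cl)cn4)[C@@H]3C2)nc2ccccc21` has not yet been measured in this assay. It differs from compound 2 in one place: 5-chloropyridin-2-yl in place of 2,5-difluorophenyl on an oxygen on a saturated carbon. Among the measured compounds shown here, no measured pair in this set isolates such a change, so the expectation rests on compound 2 alone and on the change being confined to the ether aryl group while the rest of the molecule is kept.

The step from compound 2 to compound 3 is expected to be small and, if anything, toward a somewhat higher number, a 2.9-fold higher number from compound 2 to compound 3 (0.46 log units; beyond the scatter). For compound 3 the estimate in this assay is 20 nM, within a range of 5 nM to 80 nM.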

Compound 3, half-maximal effective concentration: 26 nM
The estimate for compound 3 lay 1.3-fold (0.11 log units) below the measured number; the range from low to high includes it.
By their numbers in this assay, from the lowest: compound 2; then compound 3; then compound 1.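

Among these compounds, compound 3 gives the first one-place reading at this position in this assay: on an oxygen on a saturated carbon, 5-chloropyridin-2-yl in place of 2,5-difluorophenyl gives a 3.7-fold higher number from compound 2 to compound 3 (0.57 log units; beyond the scatter) as a modest step. The position therefore accepts a six-membered aromatic ring with a hetero atom and a hydrogen-bond acceptor in place of a ring of carbon only, and compound 3 at 26 nM remains in the nanomolar range, though the step is beyond the usual scatter and goes toward a higher number. No measurement shown here bears on the reason for this step.

The change exchanges the ring nitrogen and the halogens together, so the compounds shown do not separate the contribution of the nitrogen from that of the chlorine or of the loss of the two fluorines. On these data alone, it also remains open how this position would read in the same assay with a non-aromatic group on the oxygen, such as a saturated chain carrying an amine or a carboxylic acid, in place of either aryl group.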